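Removing an isopropyl from the indazole nitrogen of compound 2

A few compounds are considered here, and "the series" means these few. Any claim that something is new, unique, unknown or untested is made for them only; others in the source may bear on it.

Measured compounds:
- compound 1, `O=[N+]([O-])c1ccccc1CNc1cccc2[nH]ncc12`: 17000 nM
- compound 2, `CC(C)n1ncc2c(NCc3ccccc3[N+](=O)[O-])cc(C(F)(F)F)cc21`: > 100000 nM

In an assay for inhibition of Tryptophan 2,3-dioxygenase (Homo sapiens), with stated times of 10 min and 60 min (a higher number here means a weaker inhibitor, a lower number a stronger inhibitor), compound 2 gives only > 100000 nM, which is a limit of the assay and not a number. That is the limit of > 100000 nM in this assay, at which 1 of the 2 values shown sits, so compound 2 stands at the weak end of what is shown. Compound 3, `O=[N+]([O-])c1ccccc1CNc1cc(C(F)(F)F)cc2[nH]ncc12`, differs from compound 2 by hydrogen in place of isopropyl on an aromatic nitrogen. Compound 1, which carries hydrogen at that same nitrogen, gives 17000 nM in this assay, so a step toward a lower number, beyond the scatter, is expected from compound 2 to compound 3, an at least 3.3-fold lower number from compound 2 to compound 3 (0.52 log units; beyond the scatter). Compound 3 is therefore estimated at 30000 nM, within 8000 nM to 110000 nM.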

Compound 3, half-maximal inhibitory concentration: 2550 nM
Estimate against measurement, compound 3: 12-fold (1.07 log units) above; the whole stated range lies above it.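

The step of an at least 39-fold lower number from compound 2 to compound 3 (1.59 log units; beyond the scatter) shows that, with the trifluoromethyl kept, hydrogen on this aromatic nitrogen is far better than isopropyl. The step of a 6.7-fold lower number from compound 1 to compound 3 (0.82 log units; beyond the scatter) shows that, with hydrogen on that nitrogen, adding trifluoromethyl on the aromatic carbon also lowers the number, so this group is tolerated once the isopropyl is gone. The value for compound 2 is a limit and not a number: the limit of > 100000 nM in this assay, at which 1 of the 3 values shown sits. As far as these compounds go, how a methyl on that nitrogen would read stays open, and so does a nitrile in place of the trifluoromethyl.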